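Moving the chlorine on the pyridine ring of a CXCR4 antagonist

A few compounds are considered here, and "the series" means these few. Any claim that something is new, unique, unknown or untested is made for them only; others in the source may bear on it.

Measured compounds:
compound 1, `c1ccc(NCc2ccc(CNc3ncccn3)cc2)cc1`: 55%
compound 2, `c1ccc(NCc2ccc(CNc3ncccn3)cc2)nc1`: 58%
compound 3, `Clc1ccc(NCc2ccc(CNc3ncccn3)cc2)nc1`: 82%

All three share one core and differ only in the group on the amine nitrogen. In a functional assay on MDA-MB-231 cells for antagonist activity at C-X-C chemokine receptor type 4 (Homo sapiens), tested at 10 nM (on this read-out lower numbers stand for a weaker effect and higher numbers for a stronger effect at the one concentration tested), compound 3 gives the highest number of the three, and both of its steps from the others lie beyond the scatter: a number 27 percentage points higher from compound 1 to compound 3 (beyond the scatter) and a number 24 percentage points higher from compound 2 to compound 3 (beyond the scatter). The step of a number 3 percentage points higher from compound 1 to compound 2 (within the scatter) is within the scatter, so the gain belongs to the chlorine rather than to the pyridine nitrogen.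

Compound 4, `Clc1cccc(NCc2ccc(CNc3ncccn3)cc2)n1`, keeps every atom of compound 3 but joins them differently: 6-chloropyridin-2-yl in place of 5-chloropyridin-2-yl on an amine nitrogen. Within the data shown here, no measured step moves the chlorine from one position to another; the steps that bear on it only show that a chlorine at the 5-position helps. As far as these compounds go, whether a chlorine at the 6-position does the same is unknown, so a step downward of modest size is expected, a number 14 percentage points lower from compound 3 to compound 4 (beyond the scatter), with wide uncertainty. Compound 4 is estimated to give 68% in this assay, between 50% and 85%.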

Compound 4, a percentage reported as inhibition, at one concentration (the size of the read-out at that concentration, not a potency): 100%
The estimate for compound 4 lay 32 percentage points below the measured number; measured number outside the range, above it.
By their numbers in this assay, from the lowest: compounds 1 and 2 (each within the scatter of the next); then compound 3; then compound 4.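

The place of the chlorine on the pyridine ring matters as well as its presence: with the same atoms joined differently, the 6-chloropyridin-2-yl group gives a number 18 percentage points higher from compound 3 to compound 4 (beyond the scatter) and so outperforms the 5-chloropyridin-2-yl group. Adding this chlorine to the unsubstituted pyridine gives a number 42 percentage points higher from compound 2 to compound 4 (beyond the scatter), a larger gain than the 5-chloropyridin-2-yl group gave, and the full change from phenyl on the amine nitrogen gives a number 45 percentage points higher from compound 1 to compound 4 (beyond the scatter). Nothing available explains why this placement does better.

In this assay, as far as these compounds go, compound 4 gives 100% at a single concentration, so how much stronger it is than compound 3 across a range of concentrations remains unknown. From the compounds shown here alone, whether a methyl or a methoxy group in place of this chlorine would do as well also remains open.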